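A Benzylcarbamoyl Exchange in a Close Pair

The source may hold more compounds than are shown below. What is called first, only, known or untested is meant among the compounds shown, and "the series" means these compounds.

In a physicochemical assay for solubility, in phosphate buffer, at pH 6.5 (a higher number here means a more soluble compound, a lower number a less soluble compound), compound 1 `C=C[C@@H]1C[C@]1(NC(=O)[C@@H]1C[C@@H](Oc2nccc3cc(OC)ccc23)CN1C(=O)[C@@H](NC(=O)N[C@H](COC)C(C)C)C(C)(C)C)C(=O)NS(=O)(=O)C1CC1` gives 570 ug/mL and compound 2 `C=C[C@@H]1C[C@]1(NC(=O)[C@@H]1C[C@@H](Oc2nccc3cc(OC)ccc23)CN1C(=O)[C@@H](NC(=O)N[C@H](COC)C(C)(C)C)C(C)(C)C)C(=O)NS(=O)(=O)C1CC1` gives 609 ug/mL. Within the data shown here, the one measured step, a 1.1-fold higher number from compound 1 to compound 2 (0.03 log units; within the scatter), lies within the scatter, so compound 2 stands level with compound 1 on these numbers. Compound 3 `C=C[C@@H]1C[C@]1(NC(=O)[C@@H]1C[C@@H](Oc2nccc3cc(OC)ccc23)CN1C(=O)[C@@H](NC(=O)N[C@H](C(=O)NCc1ccccc1)C(C)(C)C)C(C)(C)C)C(=O)NS(=O)(=O)C1CC1` keeps the core of compound 2 but carries benzylcarbamoyl in place of methoxymethyl on a saturated chain carbon bound to an amide-type nitrogen and a saturated chain carbon. Among the measured compounds shown here, the measured step is only methyl in place of hydrogen, elsewhere on the chain, and no measured step covers an exchange of this size. The data therefore give little guidance, and the expectation of a lower number in this assay rests on the structural change alone. The expected size is a 3.0-fold lower number from compound 2 to compound 3 (0.48 log units; beyond the scatter). For compound 3 the estimated value is 200 ug/mL, with an expected range from 50 ug/mL to 600 ug/mL.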

Compound 3, solubility: 95 ug/mL
Beside the measured number, compound 3's estimate is 2.1-fold (0.32 log units) above it; the range from low to high includes it.
By their numbers in this assay, from the lowest: compound 3; then compounds 1 and 2 (each within the scatter of the next).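

At this place, on a saturated chain carbon bound to an amide-type nitrogen and a saturated chain carbon, benzylcarbamoyl in place of methoxymethyl gives in this assay a 6.4-fold lower number from compound 2 to compound 3 (0.81 log units; beyond the scatter) and so reaches beyond the scatter, unlike the earlier methyl in place of hydrogen, which gave a 1.1-fold higher number from compound 1 to compound 2 (0.03 log units; within the scatter) within it. The entering group brings one six-membered aromatic ring of carbon only and a hydrogen-bond donor together, so this single step cannot separate what each of them contributes. Nothing in the data shown explains the lower number.

As far as these compounds go, whether carbamoyl without the benzyl would stay closer to compound 2 remains open. So does how an amine or a carboxylic acid on the same carbon would read in this assay here.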